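The source may hold more compounds than are shown below. What is called first, only, known or untested is meant among the compounds shown, and "the series" means these compounds.

Measured so far in a functional assay on OVCAR-3 cells (Homo sapiens) for inhibition; a higher number here means a weaker inhibitor, a lower number a stronger inhibitor:
compound 1 `N#CC1CN1C(=O)Nc1ccc(S(N)(=O)=O)cc1` gives 188000 nM
compound 2 `N#CC1CN1C(=O)Nc1cccnc1` gives 10000 nM

Compound 1 holds the higher of the two numbers in this assay; compound 2 sits at a lower number, a gap beyond the scatter. Compound 3 `N#CC1CN1C(=O)Nc1ccccc1` is not yet measured. It differs from compound 1 by hydrogen in place of sulfamoyl on an aromatic carbon. Among the compounds with values here, no measured pair shows this change on its own, so its size is open. The expected step of a 6.3-fold lower number from compound 1 to compound 3 (0.80 log units; beyond the scatter) would be toward a lower number and beyond the scatter. Compound 3 is estimated at 30000 nM, within a range from 5000 nM to 200000 nM.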

Compound 3, half-maximal inhibitory concentration: 6800 nM
Estimate against measurement, compound 3: 4.4-fold (0.64 log units) above, within the range that was stated.
By their numbers in this assay, from the lowest: compounds 3 and 2 (each within the scatter of the next); then compound 1.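

Hydrogen in place of sulfamoyl on an aromatic carbon gives a 28-fold lower number from compound 1 to compound 3 (1.44 log units; beyond the scatter) in this assay. This is the first change in a single place among these compounds, and it shows that what this position carries can move the number by a large step, with compound 3 the stronger inhibitor of the pair. Nothing measured here accounts for the size of this step. On these data alone, whether an amine or a carboxylic acid at this position would stay close to compound 3 or move toward compound 1 remains open. So does whether sulfamoyl would give the same step on another aromatic carbon.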